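Chloro to methyl on a compound at the assay limit

The source may hold more compounds than are shown below. What is called first, only, known or untested is meant among the compounds shown, and "the series" means these compounds.

Measured in a functional assay on A549 cells (Homo sapiens) for antiproliferative activity, read by XTT assay, with a stated time of 24 h; on this read-out lower numbers stand for stronger inhibition and higher numbers for weaker inhibition:
Compound 1 `Fc1ccc(C2CC(c3ccc(Cl)s3)=NN2c2nc(-c3ccc(C(F)(F)F)cc3)cs2)cc1`: > 500 ug/mL, a limit
Compound 2 `CS(=O)(=O)c1ccc(-c2csc(N3N=C(c4ccc(Cl)s4)CC3c3ccc(F)cc3)n2)cc1`: > 500 ug/mL, a limit

Compound 1 has no exact number on this scale, because its > 500 ug/mL is only a limit. Compound 2 gives no exact number either: the limit of > 500 ug/mL in this assay, at which 2 of the 2 values shown sit.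

Compound 3 `Cc1ccc(C2=NN(c3nc(-c4ccc(C(F)(F)F)cc4)cs3)C(c3ccc(F)cc3)C2)s1` keeps the core of compound 1 but has methyl in place of chloro on an aromatic carbon, turning 5-chlorothiophen-2-yl into 5-methylthiophen-2-yl: methyl in place of chloro on an aromatic carbon. Within the data shown here, the only measured step, a step that the two limits leave unreadable from compound 1 to compound 2, lies at another place and offers no size to carry over. Among the measured compounds shown here, with no measured step at this place, no change beyond the scatter is expected in this assay, and no direction can be named. The expected result is a number no higher from compound 1 to compound 3 (the limit leaves the size open). For compound 3 the estimate is 500 ug/mL, with an expected range of 150 ug/mL to 1000 ug/mL.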

Compound 3, half-maximal inhibitory concentration: > 500 ug/mL
Compound 3: only a limit was reported; the forecaster's own chance of this, stated with the estimate: 75%; the middle value lies on the limit itself.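

No new step can be read from compound 1 to compound 3, because each of the two values is a limit and not a number: the limit of > 500 ug/mL in this assay, at which 3 of the 3 values shown sit.

Whether methyl in place of chloro changes the activity at all, and in which direction, stays open with the compounds shown.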